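This account rests on a few compounds, and the source may have more. Where it says the series, first, only, none or still open, it means among the compounds named here.

Measured so far:
compound 1, `COC(=O)C1=C(C)N=C(C)/C(=C(\O)OC)C1c1cccc(OC(=O)c2ccccc2)c1`, 6310 nM;
compound 2, `COC(=O)C1=C(C)N=C(C)/C(=C(\O)OC)C1c1cccc(I)c1`, 41.7 nM;
compound 3, `COC(=O)C1=C(C)N=C(C)/C(=C(\O)OC)C1c1cccc(N(C)C)c1`, 891 nM.

In a functional assay (muscle tissue) with Cavia porcellus as the target (a lower number here means that less compound is needed, a higher number that more compound is needed for the effect), compound 3 stands second highest of the three numbers: compound 1 lies a 7.1-fold lower number from compound 1 to compound 3 (0.85 log units; beyond the scatter) above it, while compound 2 lies a 21-fold higher number from compound 2 to compound 3 (1.33 log units; beyond the scatter) below it. Compound 4, `COC(=O)C1=C(C)N=C(C)/C(=C(\O)OC)C1c1cccc([N+](=O)[O-])c1`, differs from compound 3 by nitro in place of dimethylamino on an aromatic carbon. Both earlier steps at this same aromatic carbon were large, and the smallest group there, iodo, gave the lowest number, whereas the bulky benzoyloxy gave the highest. Nitro is small like iodo, so compound 4 is expected to move toward compound 2 with a step of a 15-fold lower number from compound 3 to compound 4 (1.17 log units; beyond the scatter). Compound 4 is therefore estimated at 60 nM, ranging from 12 nM to 300 nM.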

Compound 4, half-maximal effective concentration: 3.98 nM
Beside the measured number, compound 4's estimate is 15-fold (1.18 log units) above it; the measured number lies below the stated range.
By their numbers in this assay, from the lowest: compound 4; then compound 2; then compound 3; then compound 1.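

In this assay, nitro and dimethylamino hold the same count of heavy atoms, yet the change gives a 220-fold lower number from compound 3 to compound 4 (2.35 log units; beyond the scatter), so that count alone does not order the groups at this aromatic carbon. Nitro also displaces iodo as the group with the lowest number, with a 10-fold lower number from compound 2 to compound 4 (1.02 log units; beyond the scatter), and the span at this position widens to a 1600-fold lower number from compound 1 to compound 4 (3.20 log units; beyond the scatter). Nothing available here accounts for these steps.

On these data alone, whether a nitrile or a carboxylic acid at this aromatic carbon would come close to compound 4 remains open. So does whether nitro would keep this number on another carbon of the ring.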